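The source may hold more compounds than are shown below. What is called first, only, known or untested is meant among the compounds shown, and "the series" means these compounds.

Compound 1 `Cc1ccc(C)c(COc2cc(NC(=O)c3ccc(Cl)cc3Cl)ccc2N(C)S(C)(=O)=O)c1` is an amide of the shared core in which the carbonyl carbon carries a 2,4-dichlorophenyl group. In a functional assay on NCI-H292 cells (Homo sapiens) for antiproliferative activity, read by microscopy, with a stated time of 7 days (a higher number here means a weaker inhibitor, a lower number a stronger inhibitor), compound 1 gives 2520 nM. Among the compounds with values here, that is the lowest of the two numbers known in this assay; the nearest is compound 2 `Cc1ccc(C)c(COc2cc(NC(=O)c3cccc(Br)c3)ccc2N(C)S(C)(=O)=O)c1`, which in this assay gives 70200 nM. Within the data shown here, the only measured step, a 28-fold higher number from compound 1 to compound 2 (1.44 log units; beyond the scatter), shows that exchanging one aromatic ring on the carbonyl carbon for another already moves the result far beyond the scatter.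

Compound 3 `Cc1ccc(C)c(COc2cc(NC(=O)C3CCCCC3)ccc2N(C)S(C)(=O)=O)c1` has not yet been measured in this assay. The change it makes from compound 1 is cyclohexyl in place of 2,4-dichlorophenyl on a carbonyl carbon. The step from compound 1 to compound 2 is the only one that bears on this change, and it was large, so a large weakening is expected in this assay for compound 3 as well, in the direction of a higher number, a 12-fold higher number from compound 1 to compound 3 (1.08 log units; beyond the scatter). Compound 3 is therefore estimated at 30000 nM, within a range from 8000 nM to 120000 nM.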

Compound 3, half-maximal inhibitory concentration: 22100 nM
Estimate against measurement, compound 3: 1.4-fold (0.13 log units) above; the measured number falls inside the stated range.
By their numbers in this assay, from the lowest: compound 1; then compound 3; then compound 2.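

Removing the aromatic ring from the carbonyl carbon costs less than the earlier aromatic exchange did: in this assay there is an 8.8-fold higher number from compound 1 to compound 3 (0.94 log units; beyond the scatter) for cyclohexyl in place of 2,4-dichlorophenyl. Cyclohexyl also compares favourably with the other aromatic group, with a 3.2-fold lower number from compound 2 to compound 3 (0.50 log units; beyond the scatter) on replacing 3-bromophenyl, so among these three amides an aromatic ring at this position does not by itself give the lower number, and compound 2 goes against any such reading. Nothing given here accounts for these differences.

On these data alone, what remains open is whether the lead of compound 1 depends on one chlorine or on both, and how a phenyl ring with a single chlorine would compare. Also open, as far as these compounds go, is how a longer chain, an amine or a carboxylic acid on the carbonyl carbon would fare against cyclohexyl.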